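The source may report more compounds than this note shows. Statements on the series, on what has been measured and on what is new or still open speak of the compounds shown alone.

Compound 1, `Nc1cc(N)c2nc(-c3ccccc3)c(NCc3ccc(Cl)c(Cl)c3)nc2c1`, gives 9550 nM in a functional assay on SK-MEL-2 cells (Homo sapiens) for inhibition, read by sulforhodamine B assay, with a stated time of 48 h; on this read-out lower numbers stand for higher toxicity in this test and higher numbers for lower toxicity in this test.
Compound 2, `CCOC(=O)[C@H](CCC(=O)O)NC(=O)c1ccc(Sc2nc3cc(N)cc(N)c3nc2-c2ccccc2)cc1`, gives only the limit < 100000 nM.
Compound 3, `Nc1cc(N)c2nc(-c3ccccc3)c(Sc3ccc(F)cc3)nc2c1`, gives only the limit < 100000 nM.

Among these three, compound 1 is the only one with a number; compound 3 stands at a limit, and the same holds for compound 2, as the summary the limit of < 100000 nM in this assay, at which 2 of the 3 values shown sit, records. Compound 4, `Nc1cc(N)c2nc(-c3ccccc3)c(Sc3ccc(Cl)c(Cl)c3)nc2c1`, differs from compound 3 in one place: 3,4-dichlorophenyl in place of 4-fluorophenyl on a sulfur. Among the measured compounds shown here, no step between two measured compounds reaches from one value to another here, so there is no measured step to lean on. What the data do offer is compound 1, which carries the same 3,4-dichlorophenyl group on a different linker and reaches 9550 nM. On that basis compound 4 is expected to turn the limit of compound 3 into a number, with the step that the limit leaves unreadable from compound 3 to compound 4 read as an expectation rather than a measurement. The estimate for compound 4 in this assay is 15000 nM, with a range from 3000 nM to 70000 nM.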

Compound 4, concentration lethal to 50% of the cells: < 100000 nM
Compound 4 gave a limit, no number; the forecaster's own chance of this, stated with the estimate: 40%; the middle value is on the limit's open side.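

Among the compounds shown here, compound 3 and compound 4 both give only a limit in this assay, and no step between them can be read. The compounds shown leave open where the values of compound 3 and compound 4 lie, and whether 3,4-dichlorophenyl in place of 4-fluorophenyl on a sulfur changes toxicity in this test at all.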